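Swapping the Naphthyl Arm for a Methoxyphenyl

A few compounds are considered here, and "the series" means these few. Any claim that something is new, unique, unknown or untested is made for them only; others in the source may bear on it.

Measured compounds:
compound 1, `COc1cc(C2CC(c3cccc4ccccc34)=NN2C(C)=O)ccc1OCc1cn(Cc2ccc([N+](=O)[O-])cc2)nn1`, 72%
compound 2, `CC(=O)N1N=C(c2ccc(OCc3cn(Cc4ccc([N+](=O)[O-])cc4)nn3)cc2)CC1c1ccccc1`, 55%

Of the compounds shown here, two have been tested in a functional assay on COLO 205 cells (Homo sapiens) for inhibition, read by sulforhodamine B assay, tested at 100 uM; on this read-out lower numbers stand for less inhibition of growth and higher numbers for more inhibition of growth at the one concentration tested. Compound 1 stands highest of the two numbers; its nearest neighbour, compound 2, sits a number lower that falls beyond the usual scatter. Among the compounds with values here, no pair of these two differs in a single place, so the gap between them is reported only as what the two values show.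

Compound 3, `COc1ccc(C2=NN(C(C)=O)C(c3ccc(OCc4cn(Cc5ccc([N+](=O)[O-])cc5)nn4)c(OC)c3)C2)cc1`, is not yet measured. It differs from compound 1 as follows: 4-methoxyphenyl in place of naphthalen-1-yl on a carbon with a double bond to nitrogen. Within the data shown here, the only guide to this change is the lower number seen for compound 2, a compound in which the naphthalen-1-yl is also absent; the author therefore expects the step of a number 14 percentage points lower from compound 1 to compound 3 (beyond the scatter) to be a moderate drop rather than none. Compound 3 is estimated to give 58%, within a range from 40% to 75%.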

Compound 3, percent growth inhibition at one concentration: 75%
The estimate for compound 3 lay 17 percentage points below the measured number, within the range that was stated.
By their numbers in this assay, from the lowest: compound 2; then compounds 1 and 3 (each within the scatter of the next).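

In this assay, placing 4-methoxyphenyl in place of naphthalen-1-yl on a carbon with a double bond to nitrogen gives a number 3 percentage points higher from compound 1 to compound 3 (within the scatter), so the swap leaves the read-out unresolved from the starting value. With the rest of compound 1 held fixed, this carbon therefore keeps its number with one six-membered aromatic ring carrying a methoxy group instead of the two rings of naphthalen-1-yl, and the lower number of compound 2, which differs from compound 1 in more than one place, cannot be tied to this position alone. Nothing at hand gives a reason for this outcome.

The compounds shown leave open whether a morpholine, a carboxylic acid or a short alkyl chain on this carbon would hold the number. Going by these compounds, each value also comes from a single concentration, so how compound 1 and compound 3 compare at lower concentrations remains unknown.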